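Swapping Chlorophenyl for Bromophenyl on a Shared Core

The compounds below may be only part of what the source reports. "The series", "measured", "known", "first", "only" and "open" are said of these compounds alone.

Of the compounds shown here, three built on one shared core have been tested in a functional assay on U-937 cells (Homo sapiens) for cytotoxicity, read by MTT assay, with a stated time of 48 h; on this read-out higher numbers stand for weaker inhibition and lower numbers for stronger inhibition. Compound 1 `Fc1cccc(-c2nc(Nc3ccccc3)c3ccccc3n2)c1` gives only the assay limit, > 50000 nM. Compound 2 `Fc1ccc(Nc2nc(-c3cccc(F)c3)nc3ccc(F)cc23)cc1` likewise reaches only the limit, > 50000 nM. Within the data shown here, compound 3 `Fc1cccc(-c2nc(Nc3ccc(Cl)cc3)c3cc(F)ccc3n2)c1` is the single member with a measured number, giving 32700 nM in this assay, and it stands alone because the other two results sit at the limit of > 50000 nM in this assay, at which 2 of the 3 values shown sit. Among the measured compounds shown here, the one measured step runs an at least 1.5-fold lower number from compound 2 to compound 3 (0.18 log units; that floor lies within the scatter), and its size is only a floor, since compound 2 carries no number of its own.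

Compound 4 `Fc1cccc(-c2nc(Nc3ccccc3Br)c3cc(F)ccc3n2)c1` differs from compound 3 by 2-bromophenyl in place of 4-chlorophenyl on a nitrogen on an aromatic ring. For the measured compounds named here, no measured step involves a 2-bromophenyl group, so the only guide is the single halogen swap already seen, which was itself within the scatter. A change of this kind is therefore not expected to move the number beyond the scatter in either direction. The expected step is a 1.1-fold higher number from compound 3 to compound 4 (0.03 log units; within the scatter). Compound 4 is estimated at 35000 nM, with a range from 12000 nM to 100000 nM, and a fair chance that only the limit is reported.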

Compound 4, half-maximal inhibitory concentration: > 50000 nM
Compound 4 ended at the assay's limit; the forecaster's own chance of this, stated with the estimate: 40%; middle value at least 1.4-fold (0.15 log units) away from the limit.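

Putting 2-bromophenyl in place of 4-chlorophenyl on a nitrogen on an aromatic ring gives an at least 1.5-fold higher number from compound 3 to compound 4 (0.18 log units; that floor lies within the scatter), so this change does not keep a readable number in this assay, although the floor of the step alone does not pass the usual scatter. The step from compound 2 to compound 4 cannot be read, since both ends are limits and not numbers. Among these compounds, compound 3 stays the only member with a number of its own, and this position has so far given no result clearly separated from the others: the limit of > 50000 nM in this assay, at which 3 of the 4 values shown sit.

The swap from 4-chlorophenyl to 2-bromophenyl alters both the halogen and its place on the phenyl ring, so the compounds shown cannot tell which of the two matters, or how far any of these compounds lies past the limit. Going by these compounds, it also stays open whether a phenyl ring on that nitrogen carrying an amine or a carboxylic acid, rather than a halogen, would give a number clearly lower than that of compound 3, which is 32700 nM.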